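Moving a Methoxy Group on the Benzyl Ring

The source may report more compounds than this note shows. Statements on the series, on what has been measured and on what is new or still open speak of the compounds shown alone.

Of the compounds shown here, two sharing one core have been tested in a functional assay on ASPC1 cells (Homo sapiens) for inhibition, read by MTT assay, with a stated time of 72 h; a higher number here means a weaker inhibitor of growth, a lower number a stronger inhibitor of growth. Compound 1 `O=S(=O)(NCCCNCc1ccccc1Cl)c1cc(C(F)(F)F)cc(C(F)(F)F)c1` gives 13000 nM. Among the compounds with values here, compound 2 `COc1cccc(CNCCCNS(=O)(=O)c2cc(C(F)(F)F)cc(C(F)(F)F)c2)c1` gives 3800 nM, the lower of the two numbers, and the only measured step, a 3.4-fold lower number from compound 1 to compound 2 (0.53 log units; beyond the scatter), is modest. Compound 3 `COc1ccccc1CNCCCNS(=O)(=O)c1cc(C(F)(F)F)cc(C(F)(F)F)c1` differs from compound 2 by 2-methoxyphenyl in place of 3-methoxyphenyl on a saturated chain carbon bound to an amine nitrogen. Within the data shown here, no measured step moves the methoxy group alone, so the step from compound 1 to compound 2 bears on this change only loosely, and the expected step is a 1.3-fold higher number from compound 2 to compound 3 (0.12 log units; within the scatter), small enough to sit within the scatter. Compound 3 is therefore estimated at 5000 nM, with a range of 1800 nM to 14000 nM.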

Compound 3, concentration for 50% growth inhibition: 4600 nM
Compound 3: middle estimate off by 1.1-fold (0.04 log units), on the high side; measured number inside the range.
By their numbers in this assay, from the lowest: compounds 2 and 3 (each within the scatter of the next); then compound 1.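

In this assay, moving the group from 3-methoxybenzyl to 2-methoxybenzyl gives a 1.2-fold higher number from compound 2 to compound 3 (0.08 log units; within the scatter), so the two placements of methoxy cannot be told apart here. Methoxy in place of chloro on an aromatic carbon gives a 2.8-fold lower number from compound 1 to compound 3 (0.45 log units; beyond the scatter), a single change of group with its place kept, and both methoxy compounds give lower numbers than compound 1. No measured evidence here says why these numbers fall as they do. Still open, on these data alone, is whether a hydroxy group or a nitrile in place of methoxy would give a similar number. As far as these compounds go, a longer chain in the shared core is equally open.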